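Halogen swap on the shared core: chloro to fluoro

This account rests on a few compounds, and the source may have more. Where it says the series, first, only, none or still open, it means among the compounds named here.

Measured in an ADME assay on L1210/0 cells (Mus musculus) for cytotoxicity, with a stated time of 48 h; on this read-out higher numbers stand for weaker inhibition and lower numbers for stronger inhibition:
- Compound 1 `O=C1O/C(=C\Cn2cc(C(F)(F)F)c(=O)[nH]c2=O)C(OCc2ccccc2)=C1OCc1ccccc1`: 2000 nM
- Compound 2 `O=C1O/C(=C\Cn2cc(Cl)c(=O)[nH]c2=O)C(OCc2ccccc2)=C1OCc1ccccc1`: 12200 nM

Compound 2 has the higher number of the pair at 12200 nM. Compound 3 `O=C1O/C(=C\Cn2cc(F)c(=O)[nH]c2=O)C(OCc2ccccc2)=C1OCc1ccccc1` is the next to be read, with the change (fluoro in place of chloro on an aromatic carbon), fluoro in place of chloro on an aromatic carbon. For the measured compounds named here, only one measured step bears on it, at the same place: chloro in place of trifluoromethyl gave a 6.1-fold higher number from compound 1 to compound 2 (0.79 log units; beyond the scatter), a modest step. A single step fixes no direction firmly, but a modest move to a lower number is expected in this assay. The expected change is a 2.4-fold lower number from compound 2 to compound 3 (0.39 log units; beyond the scatter). For compound 3 the estimate is 5000 nM, with a range of 1200 nM to 18000 nM.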

Compound 3, half-maximal inhibitory concentration: 5100 nM
Compound 3: middle estimate off by 1.0-fold (0.01 log units), on the low side; the range from low to high includes it.
By their numbers in this assay, from the lowest: compound 1; then compound 3; then compound 2.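

In this assay fluoro in place of chloro on this aromatic carbon gives a 2.4-fold lower number from compound 2 to compound 3 (0.38 log units; beyond the scatter) and fluoro in place of trifluoromethyl gives a 2.6-fold higher number from compound 1 to compound 3 (0.41 log units; beyond the scatter) so the three groups are now separated at this position, each step beyond the scatter. Fluoro takes the middle place in the order of numbers, with trifluoromethyl lowest and chloro highest. No evidence on hand accounts for this order. Still open, as far as these compounds go, is where a methyl group, a nitrile or a plain hydrogen would fall in this order. From the compounds shown here alone, whether the order holds with other groups in place of the two benzyl ethers also remains open.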